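The source may hold more compounds than are shown below. What is called first, only, known or untested is meant among the compounds shown, and "the series" means these compounds.

Working notes on the series. Compound 1 `C/C=C/C(=O)Nc1cccc(Oc2nc(Nc3ccn(C)n3)nc3c2CSCC3)c1` carries an unsaturated chain on the amide. In a functional assay on A549 cells (Homo sapiens) for antiproliferative activity, read by MTT assay, with a stated time of 72 h (on this read-out higher numbers stand for weaker inhibition and lower numbers for stronger inhibition), compound 1 gives only a limit, > 50000 nM; this is the point marked by the limit of > 50000 nM in this assay, at which 1 of the 3 values shown sits. Compound 2 `CC/C=C/C(=O)Nc1cccc(Oc2nc(Nc3ccn(C)n3)nc3c2CSCC3)c1` differs from compound 1 by methyl in place of hydrogen on a saturated chain carbon bound to a double-bonded chain carbon, and in this assay compound 2 gives 36800 nM, a step of an at least 1.3-fold lower number from compound 1 to compound 2 (0.13 log units; that floor lies within the scatter). Compound 3 `CC/C=C/C(=O)Nc1cccc(Oc2nc(Nc3cccc(OC)c3)nc3c2CSCC3)c1` exchanges the group on the aromatic nitrogen, and in this assay compound 3 gives 17200 nM, a step of a 2.1-fold lower number from compound 2 to compound 3 (0.33 log units; beyond the scatter). Compound 3 and compound 1 differ in more than one place; the difference between the two cores is not broken down here.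

Compound 4 `CCC/C=C/C(=O)Nc1cccc(Oc2nc(Nc3cccc(OC)c3)nc3c2CSCC3)c1` is not yet measured and differs from compound 3 by methyl in place of hydrogen on a saturated chain carbon, two bonds along the chain from a double-bonded chain carbon. In the earlier pair the methyl entered on a saturated chain carbon bound to a double-bonded chain carbon, whereas here it enters on a saturated chain carbon two bonds along the chain from a double-bonded chain carbon, so this is the same kind of change, not the same one. The expected step in this assay is a 1.2-fold lower number from compound 3 to compound 4 (0.09 log units; within the scatter), resting on the earlier methyl step an at least 1.3-fold lower number from compound 1 to compound 2 (0.13 log units; that floor lies within the scatter), whose floor lies within the scatter. Compound 4 is estimated at 14000 nM, between 6000 nM and 35000 nM.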

Compound 4, half-maximal inhibitory concentration: 11800 nM
Compound 4: the middle estimate sits 1.2-fold (0.07 log units) above what was measured; the range from low to high includes it.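

In this assay the added methyl gives a 1.5-fold lower number from compound 3 to compound 4 (0.16 log units; within the scatter) and so cannot be told apart from repeat scatter on this core, which means that compound 3 and compound 4 read as equal here. Compound 1 gives > 50000 nM as a limit and not as a number, and the earlier methyl step on the other core has only a floor and no fixed size. The two steps are compatible with the change carrying over from one core to the other, but they do not show that it carries over at the same size, or that it has a real effect on either core: the same change on two cores in this assay, an at least 1.3-fold lower number (0.13 log units; that floor lies within the scatter) from compound 1 to compound 2 and a 1.5-fold lower number (0.16 log units; within the scatter) from compound 3 to compound 4; the limit leaves it open whether they differ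

Still open, on these data alone, is whether a longer chain than pent-1-en-1-yl, or a chain carrying an amine, would move the number beyond the scatter in this assay on either core. Also open, as far as these compounds go, is how the pent-1-en-1-yl chain reads with 1-methyl-1H-pyrazol-3-yl on the nitrogen, a pairing that would set the two cores side by side for this chain.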